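Swapping a Furan for an Indole on a Shared Core

The source may hold more compounds than are shown below. What is called first, only, known or untested is meant among the compounds shown, and "the series" means these compounds.

Compound 1, `CCOC(=O)CCCCCOc1cccc(CN(C(=O)c2ccc(-c3ccncc3)cc2)C(C)C)c1`, compound 2, `CCOC(=O)CCCCCOc1cccc(CN(C(=O)c2ccc(-c3cnc(OC)nc3OC)cc2)C(C)C)c1`, and compound 3, `CCOC(=O)CCCCCOc1cccc(CN(C(=O)c2ccc(-c3ccoc3)cc2)C(C)C)c1`, share one core and differ only in the ring attached to an aromatic carbon of that core. In an ADME assay on HepG2 cells (Homo sapiens) for cytotoxicity, read by CellTiter-Glo and resazurin assay, with a stated time of 72 h (a higher number here means that more compound is needed for the effect, a lower number that less compound is needed), compound 1 gives > 26000 nM, which is a limit of the assay and not a number. Compound 2 gives > 26000 nM in this assay, again a limit. Compound 3 gives > 26000 nM in this assay, once more a limit. Because all three values sit at the limit of > 26000 nM in this assay, at which 3 of the 3 values shown sit, none of the steps between them can be read: a step that the two limits leave unreadable from compound 1 to compound 2, a step that the two limits leave unreadable from compound 1 to compound 3 and a step that the two limits leave unreadable from compound 2 to compound 3 are all unreadable. Compound 3 thus stands at the limit, alongside the other two.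

Compound 4, `CCOC(=O)CCCCCOc1cccc(CN(C(=O)c2ccc(-c3ccc4cc[nH]c4c3)cc2)C(C)C)c1`, is not yet measured; it differs from compound 3 as follows: 1H-indol-6-yl in place of furan-3-yl on an aromatic carbon. For the measured compounds named here, no measured step bears on this change, since none of the measured steps could be read. Going by the values given here, the only guidance is that every compound so far sits at the limit. Compound 4 is therefore expected to give about 30000 nM, within 12000 nM to 80000 nM, most likely again as a limit. The expected step is a step that the limit leaves unreadable from compound 3 to compound 4, meaning no change beyond the scatter.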

Compound 4, half-maximal effective concentration: > 26000 nM
Compound 4: no number, only a limit; the forecaster's own chance of this, stated with the estimate: 85%; the middle value does not contradict the limit.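

Compound 4, like compound 1, compound 2 and compound 3, sits at a limit and not a number in this assay, so no step among these four compounds can be read: the limit of > 26000 nM in this assay, at which 4 of the 4 values shown sit.

The compounds shown leave open whether any ring on the shared core would give a readable number in this assay.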